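The source may hold more compounds than are shown below. What is called first, only, known or untested is meant among the compounds shown, and "the series" means these compounds.

Measured so far:
compound 1 `Cc1ccc(C2=Nn3c(Cc4ccc(S(C)(=O)=O)cc4)nnc3SC2)cc1` — 38.5%
compound 2 `CS(=O)(=O)c1ccc(Cc2nnc3n2N=C(c2cc4ccccc4c(=O)o2)CS3)cc1` — 10.6%

Both numbers come from a functional assay on RAW264.7 cells (Mus musculus) for cytotoxicity, read by MTT assay, with a stated time of 48 h, tested at 100 uM; a higher number here means a stronger effect of the compound at the concentration tested, a lower number a weaker effect. Compound 1 gives 38.5% and stands highest of the two. Compound 2 gives 10.6%, lower by a margin beyond the scatter. Compound 3 `CS(=O)(=O)c1ccc(Cc2nnc3n2N=C(c2cc(Cl)sc2Cl)CS3)cc1` has not yet been measured. Against compound 1 it carries 2,5-dichlorothiophen-3-yl in place of 4-methylphenyl on a carbon with a double bond to nitrogen. Within the data shown here, no measured pair isolates this change, so its size is open; in this assay a small to moderate step downward, or none beyond the scatter, is expected. Compound 3 is estimated at 30% (range 12% to 52%), an expected step of a number 8.5 percentage points lower from compound 1 to compound 3 (within the scatter).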

Compound 3, a percentage reported as activity, at one concentration (the size of the read-out at that concentration, not a potency): 47.3%
Estimate against measurement, compound 3: 17.3 percentage points below, and the stated range covers the measured number.
By their numbers in this assay, from the lowest: compound 2; then compounds 1 and 3 (each within the scatter of the next).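

Under this assay the exchange of 4-methylphenyl for 2,5-dichlorothiophen-3-yl on the carbon with a double bond to nitrogen gives a number 8.8 percentage points higher from compound 1 to compound 3 (within the scatter) and is the first readable step at this position. A five-membered aromatic ring with one sulfur and two chlorine substituents therefore takes the place of the six-membered carbon ring with no change beyond the scatter. No measured property bears on this result. Open, on these data alone, is whether thiophen-3-yl without the two chlorine atoms would read the same. Also open, as far as these compounds go, is how a phenyl ring carrying an amine or a carboxylic acid would read at this position.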